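Benzoyl in Place of Acetyl at the Ring Amide

A few compounds are considered here, and "the series" means these few. Any claim that something is new, unique, unknown or untested is made for them only; others in the source may bear on it.

Of the compounds shown here, three have been measured for growth inhibition. Compound 1 `O=C(Nc1ccccc1C(F)(F)F)C1CCc2ccccc2N1C(=O)c1ccccc1` gives 8120 nM in a functional assay on NUGC-3 cells (Homo sapiens) for cytotoxicity, read by sulforhodamine B assay, with a stated time of 72 h; a higher number here means a weaker inhibitor of growth, a lower number a stronger inhibitor of growth. Compound 3 `O=C(Nc1ccccc1C(F)(F)F)C1CCc2ccccc2N1C(=O)c1ccccc1Cl`, which carries chloro in place of hydrogen on an aromatic carbon, gives 2730 nM; the step of a 3.0-fold lower number from compound 1 to compound 3 (0.47 log units; beyond the scatter) is modest but real. Compound 2 `CC(=O)N1c2ccccc2CCC1C(=O)Nc1cc(C(F)(F)F)cc(C(F)(F)F)c1` is a different case: in this assay compound 2 gives only > 70000 nM, a limit of the assay rather than a number, and the limit of > 70000 nM in this assay, at which 1 of the 3 values shown sits, is where it sits.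

The next compound, compound 4 `O=C(Nc1cc(C(F)(F)F)cc(C(F)(F)F)c1)C1CCc2ccccc2N1C(=O)c1ccccc1`, differs from compound 2 by phenyl in place of methyl on a carbonyl carbon, which read one bond further out is acetyl to benzoyl. Among the compounds with values here, no measured pair in this set makes exactly that change. Within the data shown here, the only guidance is that compound 1, which already bears the benzoyl group, gives 8120 nM. Compound 2, with the acetyl group, returns only a limit of the assay. Compound 4 pairs the benzoyl group of compound 1 with the aryl amide partner of compound 2. A step toward stronger inhibition, of uncertain size, is therefore expected as an at least 3.5-fold lower number from compound 2 to compound 4 (0.54 log units; beyond the scatter). Compound 4 is estimated at 20000 nM, between 5000 nM and 70000 nM, with a fair chance that only a limit is returned.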

Compound 4, concentration for 50% growth inhibition: 1680 nM
Compound 4: middle estimate off by 12-fold (1.08 log units), on the high side; the measured number lies below the stated range.
By their numbers in this assay, from the lowest: compounds 4 and 3 (each within the scatter of the next); then compound 1. At a limit, above all of these: compound 2.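

In this assay, phenyl in place of methyl on the carbonyl carbon attached to the ring nitrogen gives an at least 41-fold lower number from compound 2 to compound 4 (1.61 log units; beyond the scatter). Within the data shown here, this is the first reading at this position itself, as the only earlier step, a 3.0-fold lower number from compound 1 to compound 3 (0.47 log units; beyond the scatter), lay on an aromatic carbon of a benzoyl group already in place, and it shows that with the amide partner held fixed, the acetyl to benzoyl change separates a measurable value from no measurable value. Compound 2 stands at a limit of the assay and not at a number, so the step gives only a minimum size and the full size stays unknown: the limit of > 70000 nM in this assay, at which 1 of the 4 values shown sits.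

The pair cannot tell whether the gain requires an aromatic ring on this carbonyl carbon or would also come with a saturated group such as cyclohexyl or a longer chain such as butyl, and it says nothing about a pyridine ring there. It also leaves open whether chloro in place of hydrogen on the benzoyl group, which lowered the number for compound 3, would do the same on compound 4.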